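Alkyl thioether replacing benzyl ether on the shared core

The compounds below may be only part of what the source reports. "The series", "measured", "known", "first", "only" and "open" are said of these compounds alone.

Within the data shown here, compound 3 `CC(C(=O)NCc1ccc(C(C)(C)C)nc1OCc1ccc(F)cc1)c1ccc(NS(C)(=O)=O)c(F)c1` gives 0.8 nM in an assay on cells for antagonist activity at transient receptor potential cation channel subfamily V member 1 (Homo sapiens), read by FLIPR and calcium flux, with a stated time of 6 min (a lower number here means a stronger inhibitor, a higher number a weaker inhibitor), the second highest of the three numbers so far; compound 1 `CCC1CCN(c2nc(C(C)(C)C)ccc2CNC(=O)C(C)c2ccc(NS(C)(=O)=O)c(F)c2)CC1` gives 0.1 nM and compound 2 `CC(C)Oc1nc(C(C)(C)C)ccc1CNC(=O)C(C)c1ccc(NS(C)(=O)=O)c(F)c1` gives 2.3 nM. Compound 4 `CCCCSc1nc(C(C)(C)C)ccc1CNC(=O)C(C)c1ccc(NS(C)(=O)=O)c(F)c1` is not yet measured. The change is butylsulfanyl in place of (4-fluorobenzyl)oxy on an aromatic carbon. Among the measured compounds shown here, no measured step swaps an ether for a thioether at this position. The nearest guide, taken in reverse, is a 2.9-fold lower number from compound 2 to compound 3 (0.46 log units; beyond the scatter), while a 23-fold higher number from compound 1 to compound 2 (1.36 log units; beyond the scatter) and an 8.0-fold higher number from compound 1 to compound 3 (0.90 log units; beyond the scatter) show this site shifting numbers by modest to large amounts. Trading the aromatic ring for the butylsulfanyl chain is therefore expected to raise the number by a modest step, a 2.5-fold higher number from compound 3 to compound 4 (0.40 log units; beyond the scatter). Compound 4 is expected at 2 nM, within the range 0.6 nM to 7 nM.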

Compound 4, inhibition constant: 3.2 nM
The estimate for compound 4 lay 1.6-fold (0.20 log units) below the measured number; measured number inside the range.
By their numbers in this assay, from the lowest: compound 1; then compound 3; then compounds 2 and 4 (each within the scatter of the next).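

The butylsulfanyl chain, which has no ring, gives a 4.0-fold higher number from compound 3 to compound 4 (0.60 log units; beyond the scatter) against (4-fluorobenzyl)oxy. Against isopropoxy it gives a 1.4-fold higher number from compound 2 to compound 4 (0.14 log units; within the scatter) and so is not separated from that small ether at this position. The 4-ethylpiperidin-1-yl group remains well apart, with a 32-fold higher number from compound 1 to compound 4 (1.51 log units; beyond the scatter) on leaving it, and no supporting data explain any of these differences.

Left open is whether the sulfur link or the chain length matters more. A butoxy group or a shorter ethylsulfanyl chain on this aromatic carbon would separate the two.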